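The source may report more compounds than this note shows. Statements on the series, on what has been measured and on what is new or still open speak of the compounds shown alone.

Measured compounds in a functional assay on the whole organism with Canis familiaris (Canis lupus familiaris) as the target, at a dose of 2 mg/kg by the intravenous route; on this read-out higher numbers stand for a stronger effect at the one dose given and lower numbers for a weaker effect:
compound 1 `Cc1nc2c(SCc3ccccc3)cccn2c1N` — 0%
compound 2 `CC(=O)Nc1c(C)nc2c(OCc3ccccc3)cccn12` — 24%
compound 3 `Cc1nc2c(OCc3ccccc3)cccn2c1NC(=O)OCc1ccccc1` — 82%

Compound 2 stands second highest of the three numbers. Its nearest neighbour is compound 1, whose value is lower by more than the scatter; furthest away is compound 3, whose value is higher by more than the scatter.

Compound 4 `Cc1nc2c(OCc3ccccc3)cccn2c1N(C)C` has not yet been measured. Compared with compound 2 the change is dimethylamino in place of acetamido on an aromatic carbon.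

Going by the values given here, only one single-place step is known, a number 58 percentage points higher from compound 2 to compound 3 (beyond the scatter), and it changes what sits on the carbonyl carbon of the acetamido group rather than replacing the group itself, so it does not bear directly on the change to compound 4. Compound 1, which carries a free amino group at that place, gives a lower number than compound 2, but compound 1 also differs from compound 2 at the benzyl-bearing atom, so nothing can be read from that pair alone. Among the compounds with values here, with no step that matches the change, the direction for compound 4 is open; a modest drop or no change beyond the scatter seems as likely as a gain.

Compound 4 is therefore expected to give about 18%, within a range from 0% to 50%, which would mean a step of a number 6 percentage points lower from compound 2 to compound 4 (within the scatter).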

Compound 4, a percentage reported as inhibition, in the whole organism at one dose (the size of the read-out at that dose, not a potency): 85%
Compound 4: middle estimate off by 67 percentage points, on the low side; the whole stated range lies below it.
By their numbers in this assay, from the lowest: compound 1; then compound 2; then compounds 3 and 4 (each within the scatter of the next).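

In this assay, replacing acetamido with dimethylamino on this aromatic carbon gives a number 61 percentage points higher from compound 2 to compound 4 (beyond the scatter), a large step that involves no carbonyl and leaves no hydrogen-bond donor on the group. The earlier step at this place had kept the amide hydrogen and the carbonyl and changed only what sits on that carbonyl, so a high number could have seemed tied to a larger carbamate-type group; yet compound 3 gives 82% and compound 4 gives 85%, two values within the scatter of each other, and dimethylamino has fewer heavy atoms than acetamido and no ring. Nothing measured here accounts for the step.

The compounds shown leave open how methylamino, diethylamino or a free amine would read at this place with the benzyloxy group kept, and so whether both methyl groups of dimethylamino matter. They also leave open how compound 4 would read at other doses, since a single-dose percentage says nothing about potency.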